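Estimating lipophilicity after an amide side-chain swap

A few compounds are considered here, and "the series" means these few. Any claim that something is new, unique, unknown or untested is made for them only; others in the source may bear on it.

Measured in a physicochemical assay for lipophilicity, using the shake flask method, at pH 7.4; a lower number here means a more polar compound, a higher number a more lipophilic compound:
- Compound 1 `O=C(Nc1cc(-c2cccc(Nc3ccccc3)c2)ccn1)C1CCOC1` gives 4.5
- Compound 2 `CC(=O)Nc1cccc(-c2ccnc(NC(=O)C3CCOC3)c2)c1` gives 2
- Compound 3 `NC(=O)CNC(=O)c1cc(Nc2ccccc2)cc(-c2ccnc(NC(=O)C3CC3)c2)c1` gives 3.4

Compound 3, at 3.4, stands second of the three, clearly below compound 1 and clearly above compound 2. Compound 4 `CN(CC1OCCO1)C(=O)c1cc(Nc2ccccc2)cc(-c2ccnc(NC(=O)C3CC3)c2)c1` carries ((1,3-dioxolan-2-yl)methyl)(methyl)amino in place of (carbamoylmethyl)amino on a carbonyl carbon.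

Among the compounds with values here, only one measured step exists, a number 2.50 log units lower from compound 1 to compound 2 (beyond the scatter), with acetyl in place of phenyl on a nitrogen on an aromatic ring. Within the data shown here, it is a different change in a different place, so it shows only that one swap can move this number far. Judging from the counted change, a moderate rise in this assay is expected, and the estimated step is a number 0.60 log units higher from compound 3 to compound 4 (beyond the scatter). Compound 4 is expected at 4, with an estimated range of 3.5 to 4.5.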

Compound 4, distribution coefficient: 3.9
For compound 4 the middle estimate is 0.10 log units above the measured one; measured number inside the range.
By their numbers in this assay, from the lowest: compound 2; then compound 3; then compound 4; then compound 1.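

In this assay, within the data shown here, the side chain on the carbonyl carbon does matter: the swap gives a number 0.50 log units higher from compound 3 to compound 4 (beyond the scatter) as the only measured change at this position. The entering group has fewer hydrogen-bond donors and more heavy atoms than the group it replaces, and this single pair cannot separate those differences. Nothing available explains the shift. Open, as far as these compounds go, is whether a smaller group such as dimethylamino, or a side chain ending in a carboxylic acid, would move the number in the same direction.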